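The source may hold more compounds than are shown below. What is called first, only, known or untested is meant among the compounds shown, and "the series" means these compounds.

Working notes on the series. Compound 1 `CCOCCOc1cccc2ccc(N)nc12` is the starting point. In an assay on cells with melanin-concentrating hormone receptor 1 (Homo sapiens) as the target, read by radioligand binding (a higher number here means a weaker inhibitor, a lower number a stronger inhibitor), compound 1 gives > 2000 nM, which is a limit of the assay and not a number. Its standing on the numbers shown is therefore only a limit: the limit of > 2000 nM in this assay, at which 1 of the 3 values shown sits. Compound 2 `Nc1ccc2cccc(OCCC3CCCCC3)c2n1` gives 808 nM in this assay, and the step of an at least 2.4-fold lower number from compound 1 to compound 2 (0.39 log units; beyond the scatter) lies beyond the scatter. Compound 3 `CC(C)Oc1cccc2ccc(N)nc12` gives 437 nM in this assay, and the step of an at least 4.5-fold lower number from compound 1 to compound 3 (0.66 log units; beyond the scatter) also lies beyond the scatter.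

Compound 4 `Nc1ccc2cccc(OCCC3CC3)c2n1` is not yet measured. It differs from compound 1 by cyclopropyl in place of ethoxy on a saturated chain carbon, two bonds along the chain from an oxygen on an aromatic ring. For the measured compounds named here, the measured step that bears on it most directly is the one from compound 1 to compound 2, where a carbocycle likewise replaced ethoxy at the same place on the chain and the number fell; the step from compound 1 to compound 3 also fell. On that basis the step from compound 1 to compound 4 is expected to be an at least 2.8-fold lower number from compound 1 to compound 4 (0.45 log units; beyond the scatter), a decrease in this assay. The estimate for compound 4 in this assay is 700 nM, with a range from 250 nM to 2000 nM.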

Compound 4, half-maximal inhibitory concentration: 492 nM
Compound 4: the middle estimate sits 1.4-fold (0.15 log units) above what was measured, and the stated range covers the measured number.
By their numbers in this assay, from the lowest: compounds 3, 4 and 2 (each within the scatter of the next). At a limit, above all of these: compound 1.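

With the same count of heavy atoms leaving and entering, cyclopropyl in place of ethoxy on the saturated chain carbon gives an at least 4.0-fold lower number from compound 1 to compound 4 (0.60 log units; beyond the scatter) in this assay, so the gain seen with cyclohexyl at this place is not tied to that one ring. Ring size does not separate the two carbocycles on the numbers shown, with a 1.6-fold lower number from compound 2 to compound 4 (0.22 log units; within the scatter). The 2-cyclopropylethyl and isopropyl groups on the oxygen are not separated either, with a 1.1-fold higher number from compound 3 to compound 4 (0.05 log units; within the scatter).

On these data alone, compound 1 is a limit of the assay and not a number, so the full size of each step from it stays open: the limit of > 2000 nM in this assay, at which 1 of the 4 values shown sits. Also open is whether a carboxylic acid or a longer chain in place of cyclopropyl on this saturated chain carbon would hold the numbers at this level.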